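A few compounds are considered here, and "the series" means these few. Any claim that something is new, unique, unknown or untested is made for them only; others in the source may bear on it.

Three compounds share one core and differ only in the aryl group that sits on the amide carbonyl. In a functional assay on GTL 16 cells for antiproliferative activity against GTL 16 cell line (Homo sapiens), read by CCK-8 assay, with a stated time of 72 h (a higher number here means a weaker inhibitor, a lower number a stronger inhibitor), compound 1 `O=C(Nc1cccc(-c2oc3cc(-c4ccc(F)cc4)ccc3c(=O)c2O)c1)c1ccccc1F` gives 17400 nM. Compound 2 `Cc1ccc(C(=O)Nc2cccc(-c3oc4cc(-c5ccc(F)cc5)ccc4c(=O)c3O)c2)cc1` gives 12900 nM in this assay, and compound 3 `CCc1ccc(C(=O)Nc2cccc(-c3oc4cc(-c5ccc(F)cc5)ccc4c(=O)c3O)c2)cc1` gives 24600 nM in this assay. Compound 3 carries the largest of the three numbers, yet the step of a 1.4-fold higher number from compound 1 to compound 3 (0.15 log units; within the scatter) and the step of a 1.9-fold higher number from compound 2 to compound 3 (0.28 log units; within the scatter) both stay within the scatter, so the three compounds cannot be told apart on these measurements.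

Compound 4 `COc1ccc(C(=O)Nc2cccc(-c3oc4cc(-c5ccc(F)cc5)ccc4c(=O)c3O)c2)c(F)c1` is not yet measured. Its change from compound 3 is 2-fluoro-4-methoxyphenyl in place of 4-ethylphenyl on a carbonyl carbon. Among the measured compounds shown here, three measured steps bear on it, all at the same carbonyl: a 1.3-fold lower number from compound 1 to compound 2 (0.13 log units; within the scatter), a 1.4-fold higher number from compound 1 to compound 3 (0.15 log units; within the scatter) and a 1.9-fold higher number from compound 2 to compound 3 (0.28 log units; within the scatter). None moved beyond the scatter, so across compounds 1, 2 and 3 this part of the molecule has shown little sensitivity to small aryl changes. The expected step of a 1.4-fold lower number from compound 3 to compound 4 (0.16 log units; within the scatter) in this assay is therefore small, with no direction beyond the scatter. Compound 4 is estimated at 17000 nM in this assay, with a likely range from 7000 nM to 40000 nM.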

Compound 4, half-maximal inhibitory concentration: 15300 nM
The estimate for compound 4 lay 1.1-fold (0.05 log units) above the measured number; measured number inside the range.
By their numbers in this assay, from the lowest: compounds 2, 4, 1 and 3 (each within the scatter of the next).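

In this assay the exchange of 4-ethylphenyl for 2-fluoro-4-methoxyphenyl gives a 1.6-fold lower number from compound 3 to compound 4 (0.21 log units; within the scatter), while the comparisons with the other two compounds give a 1.2-fold higher number from compound 2 to compound 4 (0.07 log units; within the scatter) and a 1.1-fold lower number from compound 1 to compound 4 (0.06 log units; within the scatter). The earlier compounds shown here varied only small carbon or fluorine substituents on the aryl group, whereas compound 4 shows that this position can also take a fluorine and a methoxy together, with the one hydrogen-bond acceptor that this brings, and still stay within the scatter. Nothing available here explains why the number stays so flat at this position.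

All four compounds keep a substituted phenyl on the carbonyl, and every step between them stays within the scatter. On these data alone, whether an amine, a carboxylic acid or a longer chain on that phenyl could move the number beyond the scatter remains open.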